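A few compounds are considered here, and "the series" means these few. Any claim that something is new, unique, unknown or untested is made for them only; others in the source may bear on it.

Compound 1 `CCOc1ccc(OCC)c(NC(=S)NC(=O)c2ccccc2)c1` in an assay for inhibition of epoxide hydrolase 1 (Homo sapiens), read by fluorescence, using microsomes (on this read-out higher numbers stand for weaker inhibition and lower numbers for stronger inhibition), gives 2040 nM, the lowest of the two numbers in hand; compound 2 `CC(=O)NC(=S)Nc1ccc(Cl)cc1` gives 2210 nM in this assay, and the two stand within the scatter of each other. Compound 3 `CCOc1ccc(OCC)c(NC(=S)NC(C)=O)c1` has not been measured. It differs from compound 1 by methyl in place of phenyl on a carbonyl carbon, benzoyl to acetyl. Going by the values given here, no measured pair covers this change, so its size is open; compound 2 also carries acetyl and shows with 2210 nM that such compounds can land in the same range. The expected step of a 1.5-fold higher number from compound 1 to compound 3 (0.17 log units; within the scatter) is small, if anything toward weaker inhibition. Compound 3 is estimated at 3000 nM, in the range 1000 nM to 9000 nM.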

Compound 3, half-maximal inhibitory concentration: 2530 nM
Compound 3: the middle estimate sits 1.2-fold (0.07 log units) above what was measured; low and high end bracket the measured number.
By their numbers in this assay, from the lowest: compounds 1, 2 and 3 (each within the scatter of the next).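

Benzoyl to acetyl gives a 1.2-fold higher number from compound 1 to compound 3 (0.09 log units; within the scatter) in this assay and leaves the two compounds within the scatter of each other. On this carbonyl carbon, the phenyl ring can therefore give way to methyl with no readable change in inhibition. Nothing in hand bears on why this step is so small.

From the compounds shown here alone, whether this position stays as undemanding for other groups remains open, for example a longer chain such as propyl, a cyclohexyl ring or a benzyl group. A single pair also cannot show whether the same change behaves alike on other cores.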